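A few compounds are considered here, and "the series" means these few. Any claim that something is new, unique, unknown or untested is made for them only; others in the source may bear on it.

Going by the values given here, compound 3 `COc1cccc(CNCCCNc2ccnc3cc(Cc4ccc(F)cc4)ccc23)c1O` sits at the low end of the three numbers so far in a physicochemical assay for solubility, with a stated time of 18 h, at pH 7.4 (on this read-out higher numbers stand for higher solubility and lower numbers for lower solubility), where compound 3 gives 4200 nM. Compound 1 `CC(C)Cc1ccc2c(NCCCNCc3ccco3)ccnc2c1` gives 4200 nM in this assay, level with compound 3 at the digits shown, while compound 2 `COc1ccc(Oc2ccc3c(NCCCNCc4ccco4)ccnc3c2)cc1` gives 14500 nM, the highest of the three. Among the compounds with values here, the only step between compounds that differ in one place is a 3.5-fold higher number from compound 1 to compound 2 (0.54 log units; beyond the scatter), brought about by 4-methoxyphenoxy in place of isobutyl on an aromatic carbon.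

Compound 4 `Fc1ccc(Cc2ccc3c(NCCCNCc4ccco4)ccnc3c2)cc1` differs from compound 3 by furan-2-yl in place of 2-hydroxy-3-methoxyphenyl on a saturated chain carbon bound to an amine nitrogen. Within the data shown here, no measured step covers this change: the move from compound 1 to compound 2 alters the group on the aromatic carbon, not the group on the saturated chain carbon bound to the amine nitrogen. Compounds 1 and 2 carry the same (furan-2-yl)methyl group as compound 4, and their values, together with that of compound 3, all lie within a modest span. The step from compound 3 to compound 4 is therefore expected to be a 1.1-fold higher number from compound 3 to compound 4 (0.03 log units; within the scatter), with no change beyond the scatter foreseen. Compound 4 is estimated to reach 4500 nM in this assay, within a range from 1500 nM to 14000 nM.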

Compound 4, solubility: 4200 nM
Estimate against measurement, compound 4: 1.1-fold (0.03 log units) above, and the stated range covers the measured number.
By their numbers in this assay, from the lowest: compounds 1, 3 and 4 (each within the scatter of the next); then compound 2.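

In this assay, going by these compounds alone, the place on a saturated chain carbon bound to an amine nitrogen now has a reading of its own, which no earlier step gave: furan-2-yl in place of 2-hydroxy-3-methoxyphenyl shows no change at the digits printed from compound 3 to compound 4 (within the scatter) even though 9 heavy atoms give way to 5 and the 1 hydrogen-bond donor is lost. Within the data shown here, with (furan-2-yl)methyl held constant, 4-fluorobenzyl in place of 4-methoxyphenoxy on an aromatic carbon shows a 3.5-fold lower number from compound 2 to compound 4 (0.54 log units; beyond the scatter) and so gives the earlier step from the other side, while 4-fluorophenyl in place of isopropyl on a saturated chain carbon bound to an aromatic carbon shows no change at the digits printed from compound 1 to compound 4 (within the scatter) and leaves 4-methoxyphenoxy as the only group at that aromatic carbon tied to a step beyond the scatter. Nothing among the supporting data offers an account of these results.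

Going by these compounds, it remains open whether the number would stay level with a carboxylic acid or a dimethylamino group in place of furan-2-yl on that saturated chain carbon. Also open, on these data alone, is whether 4-methoxyphenoxy would bring a comparable step with 2-hydroxy-3-methoxybenzyl on the amine.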